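Chloro positional isomers in a cytotoxicity series

This account rests on a few compounds, and the source may have more. Where it says the series, first, only, none or still open, it means among the compounds named here.

Compound 1 `O=S(=O)(Nc1ccc(-c2nc3ccccc3o2)cc1)c1cccc(Cl)c1` in an ADME assay on HEK293 cells (Homo sapiens) for cytotoxicity, read by resazurin assay, with a stated time of 48 h (on this read-out higher numbers stand for lower toxicity in this test and lower numbers for higher toxicity in this test), gives > 100000 nM, which is a limit of the assay rather than a number. Compound 2 `O=S(=O)(Nc1ccc2oc(-c3ccccc3)nc2c1)c1ccc(F)c(C(F)(F)F)c1` in this assay gives > 100000 nM, likewise a limit. Both measured values share (the limit of > 100000 nM in this assay, at which 2 of the 2 values shown sit), so compound 1 stands at the limit alongside the other measured compound. Compound 3 `O=S(=O)(Nc1ccc(-c2nc3ccccc3o2)cc1)c1ccc(Cl)cc1` remains to be measured in this assay; it differs from compound 1 by 4-chlorophenyl in place of 3-chlorophenyl on a sulfonyl sulfur. Among the measured compounds shown here, no step between measured compounds is available, and no shift beyond the scatter is expected from this change. The expected step of a number no higher from compound 1 to compound 3 (the limit leaves the size open) is essentially flat. Compound 3 is estimated at 100000 nM, with a range from 50000 nM to 200000 nM, most likely reported again as a limit.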

Compound 3, half-maximal cytotoxic concentration: > 100000 nM
Compound 3: only a limit was reported; the forecaster's own chance of this, stated with the estimate: 80%; the middle value lies on the limit itself.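

Compound 1 and compound 3 both sit at the assay limit, so no step can be read for 4-chlorophenyl in place of 3-chlorophenyl on a sulfonyl sulfur. The compounds shown leave open what concentration, if any, produces toxicity in this assay.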